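A few compounds are considered here, and "the series" means these few. Any claim that something is new, unique, unknown or untested is made for them only; others in the source may bear on it.

Compound 1 `O=C(/C=C/c1ccccc1Br)NNC(=O)c1ccc2c(c1)OCCO2`: 315000 nM
Compound 2 `O=C(/C=C/c1ccccc1)NNC(=O)c1ccc2c(c1)OCCO2`: 312000 nM
Compound 3 `COc1ccccc1/C=C/C(=O)NNC(=O)c1ccc2c(c1)OCCO2`: 312000 nM

In an ADME assay on cells (Macrophage) for cytotoxicity, read by MTT assay, with a stated time of 24 h (a higher number here means that more compound is tolerated, a lower number that less compound is tolerated), compound 3 gives 312000 nM, and all three values lie within the scatter of one another, so no order among them can be read. Compound 4 `O=C(/C=C/c1ccccc1[N+](=O)[O-])NNC(=O)c1ccc2c(c1)OCCO2` carries the change (nitro in place of methoxy on an aromatic carbon). Among the compounds with values here, two measured steps touch the same place: a 1.0-fold lower number from compound 1 to compound 3 (0.00 log units; within the scatter) and no change at the digits printed from compound 2 to compound 3 (within the scatter), neither moving beyond the scatter. On that basis compound 4 is expected to show no change at the digits printed from compound 3 to compound 4 (within the scatter) in this assay. The estimate for compound 4 is 312000 nM, with a range from 156000 nM to 624000 nM.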

Compound 4, half-maximal cytotoxic concentration: 257000 nM
For compound 4 the middle estimate is 1.2-fold (0.08 log units) above the measured one, and the stated range covers the measured number.
By their numbers in this assay, from the lowest: compounds 4, 2, 3 and 1 (each within the scatter of the next).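

Nitro on this aromatic carbon stays within the scatter of all three earlier groups in this assay: against methoxy (a 1.2-fold lower number from compound 3 to compound 4 (0.08 log units; within the scatter)), against hydrogen (a 1.2-fold lower number from compound 2 to compound 4 (0.08 log units; within the scatter)) and against bromo (a 1.2-fold lower number from compound 1 to compound 4 (0.09 log units; within the scatter)). Within the data shown here, the position thus now holds a group with a double bond outside aromatic rings, and still no step goes beyond the scatter. Hydrogen, bromo, methoxy and nitro cannot be told apart here.

From the compounds shown here alone, whether an amine or a carboxylic acid on this carbon would move the number beyond the scatter stays open. Nothing shown speaks to why these numbers stay together.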